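The source may hold more compounds than are shown below. What is called first, only, known or untested is meant among the compounds shown, and "the series" means these compounds.

Measured compounds:
Compound 1, `CC(=O)NC[C@@H]1C[C@H]1c1cccc2nc(CCCCc3ccccc3)oc12`, gives 0.37 nM in an assay on NIH3T3 cells with melatonin receptor type 1B (Homo sapiens) as the target; on this read-out lower numbers stand for stronger inhibition and higher numbers for weaker inhibition.
Compound 2, `CCC(=O)NC[C@@H]1C[C@H]1c1cccc2nc(CCCCc3ccccc3)oc12`, gives 0.07 nM in this assay.

For the measured compounds named here, only one step links these two numbers: a 5.3-fold lower number from compound 1 to compound 2 (0.72 log units; beyond the scatter). Compound 2 therefore holds the lower of the two numbers, and the gap to compound 1 is beyond the scatter.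

Compound 3 is `O=C(NC[C@@H]1C[C@H]1c1cccc2nc(CCCCc3ccccc3)oc12)C1CC1`. It changes the same acyl part of the molecule once more: cyclopropyl in place of ethyl on a carbonyl carbon, that is, propanoyl becomes cyclopropylcarbonyl. The step from compound 1 to compound 2 is the only one that bears on this change, and it was modest. Nothing measured shows what happens when the ethyl is closed into a ring, so no direction can be read off with confidence; the expectation is a step of about the size of the scatter, if any, with a slightly higher number as the more likely outcome: a 1.4-fold higher number from compound 2 to compound 3 (0.15 log units; within the scatter). Compound 3 is thus estimated at 0.1 nM in this assay, with a plausible range from 0.03 nM to 0.4 nM.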

Compound 3, inhibition constant: 0.48 nM
For compound 3 the middle estimate is 4.8-fold (0.68 log units) below the measured one; the measured number lies above the stated range.
By their numbers in this assay, from the lowest: compound 2; then compounds 1 and 3 (each within the scatter of the next).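

In this assay the change from ethyl to cyclopropyl on the carbonyl carbon gives a 6.9-fold higher number from compound 2 to compound 3 (0.84 log units; beyond the scatter) and so undoes the gain seen when methyl became ethyl: adding carbon at this position does not by itself lower the number, since cyclopropyl has one more carbon than ethyl and still loses ground. For the compounds shown here, the comparison with the smallest acyl group in this set shows a 1.3-fold higher number from compound 1 to compound 3 (0.11 log units; within the scatter) and places cyclopropyl and methyl level on this read-out, which leaves compound 2 with the lowest number of the three and makes ethyl the only one of these groups to stand apart. The position therefore responds to the form of the group as well as to its carbon count, but no measurement here explains the difference.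

On these data alone, whether the low number of compound 2 extends to a longer open chain such as propyl, or to a branched one such as isopropyl, remains open. It is also unknown whether a larger ring such as cyclobutyl would track cyclopropyl or move the number in either direction.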